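The source may hold more compounds than are shown below. What is called first, only, known or untested is meant among the compounds shown, and "the series" means these compounds.

Compound 1 `COc1ccc(Br)cc1C(=O)Nc1ccc(Sc2nc3ccccc3s2)cc1` was tested in an assay for inhibition of HSP60/HSP10 (Homo sapiens), with a stated time of 60 min; a higher number here means a weaker inhibitor, a lower number a stronger inhibitor. In this assay compound 1 reaches only a limit, > 100000 nM. Compound 3 `COc1c(Br)cc(Br)cc1C(=O)Nc1ccc(Sc2nc3ccccc3s2)c(Cl)c1` likewise gives only a limit there, > 100000 nM. Compound 2 `O=C(Nc1ccc(Sc2nc3ccccc3s2)c(Cl)c1)c1cccc(Br)c1O`, by contrast, gives a number, 6900 nM. So compound 1 stands at the limit of > 100000 nM in this assay, at which 2 of the 3 values shown sit. Among the measured compounds shown here, the only measured step runs an at least 14-fold higher number from compound 2 to compound 3 (1.16 log units; beyond the scatter). Compound 4 `COc1c(Br)cccc1C(=O)Nc1ccc(Sc2nc3ccccc3s2)cc1` differs from compound 1 in that (a group of 9 heavy atoms (7 carbon, 1 oxygen, 1 bromine; one six-membered aromatic ring of carbon only) in place of a group of 9 heavy atoms (7 carbon, 1 oxygen, 1 bromine; one six-membered aromatic ring of carbon only), on a carbonyl carbon); the two have the same atoms, joined differently. For the measured compounds named here, no measured step covers this change directly, and the step from compound 2 to compound 3 suggests that the methoxy-bearing compounds 1 and 3 stay weak. Compound 4 is therefore expected to remain at the limit, a step of a number no higher from compound 1 to compound 4 (the limit leaves the size open), with an estimate of 100000 nM between 30000 nM and 300000 nM.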

Compound 4, half-maximal inhibitory concentration: > 100000 nM
Compound 4: no number, only a limit (the forecaster's own chance of this, stated with the estimate: 75%); the middle value sits exactly at the limit.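

Among the compounds shown here, compound 1 and compound 4 each give only a limit in this assay, so no step between them can be read. The compounds shown leave open whether this rearrangement of the 5-bromo-2-methoxyphenyl group changes inhibition at all.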